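The compounds below may be only part of what the source reports. "The series", "measured", "known", "first", "only" and "open" are said of these compounds alone.

Compound 1 `CCCCS(=O)(=O)Nc1cc(-c2ccc3ncnc(Nc4ccc(OCCO)nc4)c3c2)cnc1OC` gives 13300 nM in a functional assay on A549 cells (Homo sapiens) for antiproliferative activity, read by sulforhodamine B assay, with a stated time of 72 h (on this read-out higher numbers stand for weaker inhibition and lower numbers for stronger inhibition), the highest of the two numbers in hand. Compound 2 `COC(=O)Cn1cc(Nc2ncnc3ccc(-c4cnc(OC)c(NS(=O)(=O)c5ccc(F)cc5F)c4)cc23)cn1` gives 4280 nM in this assay, a number clearly lower than that of compound 1, though the two structures differ in more than one place, so nothing is attributed to a single change. Compound 3 `COc1ncc(-c2ccc3ncnc(Nc4ccc(OCCO)nc4)c3c2)cc1NS(=O)(=O)c1ccc(F)cc1F` keeps the core of compound 1 and carries 2,4-difluorophenyl in place of butyl on a sulfonyl sulfur. Among the compounds with values here, no single-point step between measured compounds is available. A moderate move toward stronger inhibition is expected, a 2.7-fold lower number from compound 1 to compound 3 (0.42 log units; beyond the scatter). Compound 3 is estimated at 5000 nM in this assay, within 1500 nM to 15000 nM.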

Compound 3, half-maximal inhibitory concentration: 4120 nM
Compound 3: the middle estimate sits 1.2-fold (0.08 log units) above what was measured, and the stated range covers the measured number.
By their numbers in this assay, from the lowest: compounds 3 and 2 (each within the scatter of the next); then compound 1.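

Within the data shown here, on the sulfonyl sulfur, 2,4-difluorophenyl in place of butyl gives a 3.2-fold lower number from compound 1 to compound 3 (0.51 log units; beyond the scatter), the first single-place reading at this position in this assay. With 2,4-difluorophenyl held there, the swap of 1-((methoxycarbonyl)methyl)-1H-pyrazol-4-yl for 6-(2-hydroxyethoxy)pyridin-3-yl on the aromatic-ring nitrogen gives a 1.0-fold lower number from compound 2 to compound 3 (0.02 log units; within the scatter), so this change shows no effect beyond the scatter. No evidence at hand bears on either step.

Open, on these data alone, is how phenyl without fluorine, or a methyl group, would read on the sulfonyl sulfur. Also open, as far as these compounds go, is whether the butyl step carries over to the pyrazolyl series.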